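Two Chlorines in Place of Two Methoxy Groups

This account rests on a few compounds, and the source may have more. Where it says the series, first, only, none or still open, it means among the compounds named here.

Of the compounds shown here, two have so far been measured in a functional assay on MOLT-4 cells (Homo sapiens) for cytotoxicity, read by MTT assay, with a stated time of 72 h; on this read-out higher numbers stand for weaker inhibition and lower numbers for stronger inhibition. Compound 1 `COc1cccc(COc2ccc3cc(C(=O)/C=C/c4cccc(OC)c4OC)c(=O)oc3c2)c1` gives 22800 nM, the higher of the two numbers and therefore the weaker of the pair. Compound 2 `COC(=O)c1ccc(/C=C/C(=O)c2cc3cc(O)ccc3oc2=O)cc1`, built on the same core but with a different pattern of substituents, gives 7100 nM; its number sits lower than that of compound 1 by a gap beyond the usual scatter, so compound 2 is the stronger of the two. For the measured compounds named here, no measured pair differs in only one place, so no single step is known yet.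

Compound 3 `COc1cccc(COc2ccc3cc(C(=O)/C=C/c4c(Cl)cccc4Cl)c(=O)oc3c2)c1` is the untested compound. It differs from compound 1 in one place: 2,6-dichlorophenyl in place of 2,3-dimethoxyphenyl on a double-bonded chain carbon bound to a double-bonded chain carbon. Nothing measured shows how this particular change acts on this core, so any expectation must rest on compound 1 alone and remain cautious. The step of a 1.5-fold lower number from compound 1 to compound 3 (0.18 log units; within the scatter) is expected to be modest, toward a somewhat lower number but possibly within the scatter. Compound 3 is accordingly expected to give about 15000 nM, with a plausible range from 5000 nM to 45000 nM.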

Compound 3, half-maximal inhibitory concentration: 12500 nM
Compound 3: the middle estimate sits 1.2-fold (0.08 log units) above what was measured, and the stated range covers the measured number.
By their numbers in this assay, from the lowest: compounds 2, 3 and 1 (each within the scatter of the next, the first and the last beyond it).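

In this assay, the swap of 2,3-dimethoxyphenyl for 2,6-dichlorophenyl on a double-bonded chain carbon bound to a double-bonded chain carbon gives a 1.8-fold lower number from compound 1 to compound 3 (0.26 log units; within the scatter), so this first single-place comparison shows no effect that can be told apart from the ordinary spread of repeated measurements. The result also shows that this position can hold quite different substituted phenyl groups, with 2 hydrogen-bond acceptors in the group that leaves and 0 in the group that enters, without a clear difference in the read-out, at least for this pair on this core. No measurement is available that would explain why these two groups read so alike.

Going by these compounds, this single pair changes both the kind of substituent and its arrangement on the ring, so the effect of each alone stays unresolved, and it remains open how a plain phenyl ring, a single chlorine, an amine or a carboxylic acid would read at the same place. Compound 2 differs from compound 3 in more than one place, so it offers no direct reading of this swap.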